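The source may report more compounds than this note shows. Statements on the series, on what has been measured and on what is new or still open speak of the compounds shown alone.

Three compounds share one core. Compound 1 `COc1ccccc1CSc1nc2cc(NC(=O)C3CC3)ccc2n1C(C)C` sits at the limit of an assay on isolated protein for inhibition of Gonadotropin-releasing hormone receptor (Rattus norvegicus); a lower number here means a stronger inhibitor, a higher number a weaker inhibitor: in this assay compound 1 gives > 10000 nM, which is a limit and not a number. Compound 2 `CC(C)n1c(SCc2ccccc2Cl)nc2cc(NC(=O)C3CC3)ccc21` in this assay likewise gives > 10000 nM, also a limit. The step that the two limits leave unreadable from compound 1 to compound 2 therefore cannot be read, because both ends rest on (the limit of > 10000 nM in this assay, at which 2 of the 3 values shown sit). Among the compounds with values here, compound 3 `CCCCn1c(SCc2cc([N+](=O)[O-])ccc2OC)nc2cc(NC(=O)NC(C)(C)C)ccc21` gives 330 nM in this assay, the only true number among the three. Compound 4 `COc1ccc([N+](=O)[O-])cc1CSc1nc2cc(NC(=O)NC(C)(C)C)ccc2n1Cc1ccncc1` differs from compound 3 by pyridin-4-yl in place of propyl on a saturated chain carbon bound to an aromatic nitrogen. Within the data shown here, no measured step touches this part of the molecule, so nothing here forecasts size or direction. The step from compound 3 to compound 4 is expected to stay within the scatter, a 1.1-fold lower number from compound 3 to compound 4 (0.04 log units; within the scatter). Compound 4 is therefore estimated at 300 nM, with a range from 80 nM to 1500 nM.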

Compound 4, half-maximal inhibitory concentration: 240 nM
Compound 4: the middle estimate sits 1.3-fold (0.10 log units) above what was measured; low and high end bracket the measured number.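

Within the data shown here, this is the first readable step at this position: in this assay, pyridin-4-yl in place of propyl on a saturated chain carbon bound to an aromatic nitrogen gives a 1.4-fold lower number from compound 3 to compound 4 (0.14 log units; within the scatter). The butyl chain can thus give way to (pyridin-4-yl)methyl, which adds an aromatic ring and a hydrogen-bond acceptor, without a change beyond the scatter. No data shown here bear on why the two compounds read alike. From the compounds shown here alone, whether this position also accepts an amine, a carboxylic acid or a longer chain remains open. A single step establishes no trend here.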